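Removing one chloro from compound 3

The source may report more compounds than this note shows. Statements on the series, on what has been measured and on what is new or still open speak of the compounds shown alone.

Measured in a functional assay on HepG2 cells (Homo sapiens) for inhibition, read by MTT assay, with a stated time of 72 h; a higher number here means a weaker inhibitor, a lower number a stronger inhibitor
compound 1 `C=C(c1ccc(Cl)c(Cl)c1)C1COC2(CCCCC2)OO1` gives 83500 nM
compound 2 `C=C(c1cc(Cl)cc(Cl)c1OCc1ccccc1)C1COC(C)(C)OO1` gives 39500 nM
compound 3 `C=C(c1ccc(Cl)c(Cl)c1Cl)C1COC2(CCCCC2)OO1` gives 9020 nM

Compound 3 at 9020 nM holds the lowest number of the three, with compound 2 nearest and compound 1 furthest. Compound 4 `C=C(c1ccc(Cl)cc1Cl)C1COC2(CCCCC2)OO1` is not yet measured. It differs from compound 3 as follows hydrogen in place of chloro on an aromatic carbon and so carries hydrogen in place of chloro on an aromatic carbon.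

Among the compounds with values here, one measured step bears on this change. It is a 9.3-fold lower number from compound 1 to compound 3 (0.97 log units; beyond the scatter) when chloro replaces hydrogen on an aromatic carbon, a modest step beyond the scatter. The change to compound 4 runs the other way and does not involve the carbon changed in that step, so the comparison is only loose. Going by a 9.3-fold lower number from compound 1 to compound 3 (0.97 log units; beyond the scatter) a higher number is expected for compound 4 in this assay and the step is expected to be of similar or somewhat smaller size, still beyond the scatter. The estimated step is a 3.9-fold higher number from compound 3 to compound 4 (0.59 log units; beyond the scatter) in this reading. For compound 4 the expected value is 35000 nM with an estimated range of 12000 nM to 90000 nM around it.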

Compound 4, half-maximal inhibitory concentration: 17600 nM
Compound 4: middle estimate off by 2.0-fold (0.30 log units), on the high side, and the stated range covers the measured number.
By their numbers in this assay, from the lowest: compounds 3 and 4 (each within the scatter of the next); then compound 2; then compound 1.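

In this assay, hydrogen in place of the chloro that is ortho to two chloro groups gives a 2.0-fold higher number from compound 3 to compound 4 (0.29 log units; within the scatter), so the two compounds cannot be told apart and this chloro is not needed to hold the reading. The earlier step, a 9.3-fold lower number from compound 1 to compound 3 (0.97 log units; beyond the scatter), added a chloro on a different aromatic carbon and lies beyond the scatter, so these two aromatic carbons do not behave alike in the two steps shown. Nothing available accounts for this difference between the two positions.

Going by these compounds, whether fluoro, methoxy or an amine on this aromatic carbon would also leave the reading within the scatter stays open. Also open, on these data alone, is whether the same change would behave the same way on the core of compound 2.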